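The source may report more compounds than this note shows. Statements on the series, on what has been measured and on what is new or still open speak of the compounds shown alone.

Compound 1 `Cc1cc(NC(=O)Nc2ccc(F)cc2)c2ccccc2n1` gives > 25000 nM in an ADME assay on HEK293 cells (Homo sapiens) for cytotoxicity, with a stated time of 72 h; on this read-out lower numbers stand for an effect already at smaller amounts and higher numbers for an effect only at larger amounts of compound; this is a limit of the assay, not a number.
Compound 2 `Cc1cc(NC(=O)Nc2ccc(F)cc2F)c2ccccc2n1` gives 10000 nM in this assay.
Compound 3 `Cc1cc(NC(=O)Nc2ccccc2F)c2ccccc2n1` gives > 25000 nM in this assay; this too is a limit of the assay.

Compound 1 thus stands at the limit of > 25000 nM in this assay, at which 2 of the 3 values shown sit, so only a limit is known for it. Compound 4 `COc1ccc(NC(=O)Nc2cc(C)nc3ccccc23)cc1` differs from compound 1 by methoxy in place of fluoro on an aromatic carbon. The measured steps concern fluoro alone: an at least 2.5-fold lower number from compound 1 to compound 2 (0.39 log units; beyond the scatter) and an at least 2.5-fold higher number from compound 2 to compound 3 (0.39 log units; beyond the scatter), while a step that the two limits leave unreadable from compound 1 to compound 3. None of them exchanges fluoro for methoxy, so none bears directly on this change. The expectation for compound 4 is therefore no step beyond the scatter, with a number no higher from compound 1 to compound 4 (the limit leaves the size open) expected, most likely again a limit. The estimated value for compound 4 is 25000 nM, between 10000 nM and 60000 nM.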

Compound 4, half-maximal effective concentration: > 25000 nM
Compound 4: only a limit was reported; the forecaster's own chance of this, stated with the estimate: 70%; the middle value sits exactly at the limit.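

Going by these compounds alone, compound 1 and compound 4 each give only a limit of the assay, so no step between them can be read: the limit of > 25000 nM in this assay, at which 3 of the 4 values shown sit. The compounds shown leave open whether methoxy in place of fluoro shifts the number in this assay at all.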